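A few compounds are considered here, and "the series" means these few. Any claim that something is new, unique, unknown or untested is made for them only; others in the source may bear on it.

Of the compounds shown here, three of one series have been measured in a functional assay on C6 cells (Rattus norvegicus) for cytotoxicity, read by MTT assay, with a stated time of 24 h, tested at 25 ug/mL; on this read-out lower numbers stand for a stronger effect and higher numbers for a weaker effect at the one concentration tested. Compound 1, `Cc1nnc(SCC(=O)N/N=c2/scc(-c3ccccc3)n2-c2ccccc2)s1`, gives 65.9% in this assay. Compound 2, `O=C(CSc1nnnn1-c1ccccc1)N/N=c1/scc(-c2ccc(F)cc2)n1-c1ccccc1`, gives 49.3%. Compound 3, `Cn1nnnc1SCC(=O)N/N=c1/scc(-c2ccc([N+](=O)[O-])cc2)n1-c1ccccc1`, gives 69.3%, the highest of the three numbers: its nearest neighbour is compound 1, whose number lies within the usual scatter of compound 3, and its furthest is compound 2, whose number lies beyond the scatter of compound 3. No pair of these compounds differs in a single place, so none of them shows directly what one change does on its own.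

Compound 4, `Cn1nnnc1SCC(=O)N/N=c1/scc(-c2ccccc2)n1-c1ccccc1`, has not been measured. It differs from compound 3 in one place: hydrogen in place of nitro on an aromatic carbon.

Since compound 1 and compound 3 carry different groups on this ring yet give numbers within the scatter of each other, the change in this assay is not expected to shift the read-out by much. Compound 4 is expected to land close to compound 3, with a step of a number 6.3 percentage points lower from compound 3 to compound 4 (within the scatter) that is not expected to reach beyond the scatter. Compound 4 is therefore estimated at 63% in this assay, between 46% and 80%.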

Compound 4, a percentage reported as activity, at one concentration (the size of the read-out at that concentration, not a potency): 64.2%
Estimate against measurement, compound 4: 1.2 percentage points below; low and high end bracket the measured number.
By their numbers in this assay, from the lowest: compound 2; then compounds 4, 1 and 3 (each within the scatter of the next).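

Going from 4-nitrophenyl to phenyl on the shared core, read in this assay, gives a number 5.1 percentage points lower from compound 3 to compound 4 (within the scatter); this is the first time that change is seen on its own, and in this one pair the read-out does not separate the two groups. A second one-place pair, at the sulfur, exchanges 5-methyl-1,3,4-thiadiazol-2-yl for 1-methyl-1H-tetrazol-5-yl and gives a number 1.7 percentage points lower from compound 1 to compound 4 (within the scatter), so this exchange on the phenyl compounds also stays inside the usual scatter. No measurement at hand bears on why either step is of this size.

From the compounds shown here alone, only nitro and hydrogen are compared at this place on the ring, so it remains open whether another group there, such as an amine, a carboxylic acid or a methoxy group, would carry the read-out beyond the scatter. Going by these compounds alone, compound 2, at 49.3% in this assay, is joined to no other compound by a one-place step, so which of its structural features goes with that number remains unresolved.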